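The source may report more compounds than this note shows. Statements on the series, on what has been measured and on what is new or still open speak of the compounds shown alone.

Compound 1 `CC(=O)N[C@@H](CSC(=O)Nc1ccc(I)cc1)C(=O)O` is the reference for the change at hand. In a functional assay on GC3/C1 cells (Homo sapiens) for cytotoxicity, read by MTT assay, with a stated time of 6 days (a higher number here means a weaker inhibitor, a lower number a stronger inhibitor), compound 1 gives > 200000 nM, which is a limit of the assay and not a number. Compound 2 `COc1ccccc1NC(=O)SC[C@H](NC(C)=O)C(=O)O` is the other measured member. In this assay compound 2 gives > 200000 nM, likewise a limit. Compound 1 therefore stands at the limit of > 200000 nM in this assay, at which 2 of the 2 values shown sit. Compound 3 `CC(=O)N[C@@H](CSC(=O)Nc1ccc(F)cc1)C(=O)O` is not yet measured; it differs from compound 1 by fluoro in place of iodo on an aromatic carbon. Within the data shown here, no step between measured compounds is available, so no shift beyond the scatter is expected in this assay, and a limit is again the likely result. Compound 3 is expected to give about 300000 nM (range 100000 nM to 1000000 nM). That estimate means an expected step that the limit leaves unreadable from compound 1 to compound 3.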

Compound 3, half-maximal inhibitory concentration: 114000 nM
Compound 3: the middle estimate sits 2.6-fold (0.42 log units) above what was measured; the measured number falls inside the stated range.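

Among these compounds, with fluoro in place of iodo on the aromatic carbon, compound 3 gives 114000 nM, the first value in this assay that is a number and not a limit. Going by these compounds, the change reads as an at least 1.7-fold lower number from compound 1 to compound 3 (0.24 log units; that floor lies within the scatter); its true size stays unknown, and this floor alone does not establish a shift beyond the scatter. The other values remain limits: the limit of > 200000 nM in this assay, at which 2 of the 3 values shown sit.

Still open, on these data alone, is how chloro, bromo or an amine at this place would read. Also open, as far as these compounds go, is whether any group here gives a number well clear of the limit.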